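The source may hold more compounds than are shown below. What is called first, only, known or untested is meant among the compounds shown, and "the series" means these compounds.

Of the compounds shown here, three have numbers so far in a functional assay on K562 cells (Homo sapiens) for antiproliferative activity, read by MTT assay, with a stated time of 48 h; a higher number here means a weaker inhibitor, a lower number a stronger inhibitor. Compound 1 (`O=C(/C=C/c1ccc(Cn2cc(Nc3ncc(Cl)c(Nc4ccc(F)cc4)n3)cn2)cc1)NO`) gives 1030 nM, compound 2 (`CNc1nc(Nc2cnn(CCCCCCC(=O)NO)c2)ncc1Cl`) gives 590 nM, and compound 3 (`O=C(CCCCCn1cc(Nc2ncc(Cl)c(Nc3ccc(Cl)cc3)n2)cn1)NO`) gives 490 nM. Compound 2 lies within the scatter of each of the other two, so these numbers set no order around it.

Compound 4 (`O=C(CCCCCCn1cc(Nc2ncc(Cl)c(Nc3ccccc3Cl)n2)cn1)NO`) differs from compound 2 in one place: 2-chlorophenyl in place of methyl on a nitrogen on an aromatic ring. In words, 2-chlorophenyl stands in place of methyl on a nitrogen on an aromatic ring, turning methylamino into (2-chlorophenyl)amino.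

Within the data shown here, no measured pair isolates this change. The closest guide is compound 3, which carries a chlorophenyl on that nitrogen but has a different chain, at 490 nM. Compound 1, with a fluorophenyl on that nitrogen and a different chain, stands at 1030 nM. Compound 2 stands at 590 nM. Neither of the other two numbers falls outside the scatter of this one, so the data give no sign that a phenyl group on that nitrogen brings a large shift.

A small move toward a lower number is expected, a 1.5-fold lower number from compound 2 to compound 4 (0.17 log units; within the scatter), and it may well stay within the scatter. For compound 4 the estimated value in this assay is 400 nM, with an expected range of 130 nM to 1200 nM.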

Compound 4, half-maximal inhibitory concentration: 860 nM
The estimate for compound 4 lay 2.2-fold (0.33 log units) below the measured number; the measured number falls inside the stated range.
By their numbers in this assay, from the lowest: compounds 3, 2, 4 and 1 (each within the scatter of the next, the first and the last beyond it).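

In this assay, among these compounds, this is the first pair that isolates the change at this position, and it gives a 1.5-fold higher number from compound 2 to compound 4 (0.16 log units; within the scatter), with 2-chlorophenyl in place of methyl on a nitrogen on an aromatic ring. Among the compounds shown here, on the same heptanoic hydroxamic acid chain and the same core, the nitrogen therefore carries either a lone methyl or a six-membered aromatic ring of carbon with its chlorine, and this single replacement gives no shift beyond the scatter, which the earlier compounds, each differing from compound 2 in more than one place, could not show. No information is available here that would account for this outcome.

For the compounds shown here, the pair tests only one aromatic group on this nitrogen, so it leaves open whether a phenyl without chlorine, or a group of another kind such as a piperidine or a carboxylic acid on a short chain, would keep the number within the scatter of compound 2. Also open is the effect of the chain on its own, since no pair shown differs in the chain alone.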